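This account rests on a few compounds, and the source may have more. Where it says the series, first, only, none or still open, it means among the compounds named here.

Compound 1 `Cc1ccc(-c2nc3cc(NC(=O)CN4CCN(C)CC4)ccc3[nH]2)cc1` gives > 50000 nM
Compound 2 `CCN1CCN(CCC(=O)Nc2ccc3[nH]c(-c4cccn4C)nc3c2)CC1` gives > 50000 nM

In a functional assay on HepG2 cells (Homo sapiens) for cytotoxicity, read by MTT assay, with a stated time of 72 h (on this read-out higher numbers stand for weaker inhibition and lower numbers for stronger inhibition), compound 1 gives > 50000 nM as a limit, not a number. Compound 2 gives > 50000 nM as a limit too. Compound 1 therefore stands with the limit of > 50000 nM in this assay, at which 2 of the 2 values shown sit, and has no number to rank it. Compound 3 `CCN1CCN(CC(=O)Nc2ccc3[nH]c(-c4ccc(C)cc4)nc3c2)CC1` carries methyl in place of hydrogen on a saturated chain carbon bound to an amine nitrogen in a ring, which turns 4-methylpiperazin-1-yl into 4-ethylpiperazin-1-yl (methyl in place of hydrogen on a saturated chain carbon bound to an amine nitrogen in a ring). No measured step sizes this change, and the expected a number no higher from compound 1 to compound 3 (the limit leaves the size open) is none beyond the scatter. Compound 3 is estimated near 50000 nM with an expected range of 20000 nM to 100000 nM and may well read as a limit again.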

Compound 3, half-maximal inhibitory concentration: 31900 nM
The estimate for compound 3 lay 1.6-fold (0.20 log units) above the measured number; low and high end bracket the measured number.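

In this assay, the change from 4-methylpiperazin-1-yl to 4-ethylpiperazin-1-yl yields a step that can be read at this position: an at least 1.5-fold lower number from compound 1 to compound 3 (0.19 log units; that floor lies within the scatter). Going by these compounds alone, compound 3 gives 31900 nM, the only number among the three compounds, yet the step does not establish a real gain in inhibition. On these data alone, the value for compound 1 is a limit and not a number, so the true size of the step stays open: the limit of > 50000 nM in this assay, at which 2 of the 3 values shown sit. As far as these compounds go, whether a longer chain such as propyl, or a hydroxyl on the ethyl, would move the number further remains open.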